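The source may report more compounds than this note shows. Statements on the series, on what has been measured and on what is new or still open speak of the compounds shown alone.

Measured in a functional assay on HL-60 cells (Homo sapiens) for inhibition, read by CCK-8 assay, with a stated time of 48 h, tested at 20 uM; a higher number here means more inhibition of growth at the concentration tested, a lower number less inhibition of growth:
compound 1 `COc1ccc(Cc2nnc(NC(=O)/C(C#N)=C/c3ccccc3OS(=O)(=O)c3ccc(OC)cc3)s2)cc1`: 100%
compound 2 `COc1ccc(S(=O)(=O)Oc2ccccc2/C=C(\C#N)C(=O)Nc2nnc(Cc3cccc(F)c3)s2)cc1`: 100%

Compound 2 stands at 100%, level with compound 1 at 100%. The next compound to be read is compound 3 `COc1ccc(S(=O)(=O)Oc2ccccc2/C=C(\C#N)C(=O)Nc2nnc(Cc3ccc(Cl)cc3)s2)cc1`, and its difference from compound 2 is 4-chlorophenyl in place of 3-fluorophenyl on a saturated chain carbon bound to an aromatic carbon. The change puts 4-chlorophenyl in place of 3-fluorophenyl on a saturated chain carbon bound to an aromatic carbon. Among the compounds with values here, one measured step bears on this place: no change at the digits printed from compound 1 to compound 2 (within the scatter), with 3-fluorophenyl in place of 4-methoxyphenyl. That single step lies within the scatter, so no step beyond the scatter is expected in this assay, and no direction is favoured. The expected step is a number 2 percentage points lower from compound 2 to compound 3 (within the scatter). Compound 3 is expected at 98%, with an estimated range of 85% to 100%.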

Compound 3, percent growth inhibition at one concentration: 99%
Beside the measured number, compound 3's estimate is 1 percentage points below it; the range from low to high includes it.
By their numbers in this assay, from the lowest: compounds 3, 1 and 2 (each within the scatter of the next).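

In this assay the 4-chlorophenyl group on a saturated chain carbon bound to an aromatic carbon gives a number 1 percentage points lower from compound 2 to compound 3 (within the scatter) and so holds the read-out where the 3-fluorophenyl group held it. Chloro in place of methoxy on an aromatic carbon gives a number 1 percentage points lower from compound 1 to compound 3 (within the scatter) and adds the comparison with the methoxy compound, so three substituted phenyl groups at this place now stand within the scatter of one another. No measurement bears on why the read-out stays unchanged across these groups.

Going by these compounds, whether an amine, a carboxylic acid or a longer chain on this ring would keep the read-out at this level stays open. With all three compounds close to complete inhibition at one concentration, these data give no order among them.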